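The source may report more compounds than this note shows. Statements on the series, on what has been measured and on what is new or still open speak of the compounds shown alone.

Of the compounds shown here, three built on one shared core have been measured in an ADME assay on Vero cells (Chlorocebus sabaeus) for cytotoxicity, read by sulforhodamine B assay, with a stated time of 48 h; on this read-out lower numbers stand for stronger inhibition of growth and higher numbers for weaker inhibition of growth. Compound 1 `COc1cc(/C(Cl)=C/C=C(\C#N)C(=O)c2c[nH]c3ccccc23)cc(OC)c1OC` gives 16200 nM, compound 2 `COc1cc(/C(Cl)=C/C=C(\C#N)C(=O)c2c(C)[nH]c3ccccc23)cc(OC)c1OC` gives 12400 nM, and compound 3 `COc1cc(/C(Cl)=C/C=C(\C#N)C(=O)c2c[nH]c3ccc(Br)cc23)cc(OC)c1OC` gives 7600 nM, the lowest of the three numbers, with compound 2 within the scatter of it and compound 1 beyond it. Compound 4 `COc1ccc2[nH]cc(C(=O)/C(C#N)=C/C=C(\Cl)c3cc(OC)c(OC)c(OC)c3)c2c1` differs from compound 3 by methoxy in place of bromo on an aromatic carbon. Going by the values given here, the only measured step touching that same aromatic carbon is a 2.1-fold lower number from compound 1 to compound 3 (0.33 log units; beyond the scatter); a methoxy there has no precedent, so removing the bromo alone would be expected to undo that modest step, while the incoming methoxy remains an open question. Among the compounds with values here, compound 4 is therefore expected near the earlier compounds, at 11000 nM with a range of 5000 nM to 25000 nM, a step of a 1.4-fold higher number from compound 3 to compound 4 (0.16 log units; within the scatter) expected to be small.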

Compound 4, concentration for 50% growth inhibition: 9500 nM
The estimate for compound 4 lay 1.2-fold (0.06 log units) above the measured number; the measured number falls inside the stated range.
By their numbers in this assay, from the lowest: compounds 3, 4, 2 and 1 (each within the scatter of the next, the first and the last beyond it).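

In this assay, methoxy in place of bromo gives a 1.3-fold higher number from compound 3 to compound 4 (0.10 log units; within the scatter), and methoxy in place of hydrogen on the same aromatic carbon gives a 1.7-fold lower number from compound 1 to compound 4 (0.23 log units; within the scatter). The new group therefore cannot be told apart from either bromo or hydrogen, even though those two are separated by a 2.1-fold lower number from compound 1 to compound 3 (0.33 log units; beyond the scatter), so this position now carries a second substituent and the read-out places it in no clear order. Nothing available explains this result.

Going by these compounds, whether an amine or a carboxylic acid on this carbon would shift the number beyond the scatter remains open. So does whether a chloro or a longer alkoxy chain would match bromo or methoxy.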